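Urea series on the shared core: chloro for methyl

The compounds below may be only part of what the source reports. "The series", "measured", "known", "first", "only" and "open" are said of these compounds alone.

Measured compounds in a functional assay on MGC-803 cells (Homo sapiens) for antiproliferative activity, read by MTT assay, with a stated time of 48 h; a higher number here means a weaker inhibitor, a lower number a stronger inhibitor:
compound 1, `O=C(Nc1cccc(CNc2nccnc2Cl)c1)NC1CCCCC1`, > 40000 nM (a limit of this assay, not a number)
compound 2, `Cc1ccc(NC(=O)Nc2cccc(CNc3nccnc3Cl)c2)c(C)c1`, 10100 nM
compound 3, `Cc1cccc(NC(=O)Nc2cccc(CNc3nccnc3Cl)c2)c1`, 14600 nM

Compound 3 and compound 2 give numbers that lie within the scatter of each other, as the step of a 1.4-fold higher number from compound 2 to compound 3 (0.16 log units; within the scatter) shows; no order between them can be read. The value of compound 1 is a limit of this assay. Against that limit both aryl ureas stand clearly apart: an at least 3.9-fold lower number from compound 1 to compound 2 (0.59 log units; beyond the scatter) and an at least 2.7-fold lower number from compound 1 to compound 3 (0.43 log units; beyond the scatter).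

Compound 4, `O=C(Nc1cccc(Cl)c1)Nc1cccc(CNc2nccnc2Cl)c1`, differs from compound 3 by chloro in place of methyl on an aromatic carbon. Going by the values given here, no measured step exchanges a methyl for a chloro, so the only bearing steps are those above: swapping one aryl group for another, as from compound 2 to compound 3, moved the number only within the scatter, while moving from cyclohexyl to either aryl group gave at least a modest change. A change of one substituent on the same aryl ring is therefore expected to stay small. The expected step is a 1.3-fold lower number from compound 3 to compound 4 (0.12 log units; within the scatter), within the scatter. Compound 4 is estimated at 11000 nM, with a range from 4500 nM to 28000 nM.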

Compound 4, half-maximal inhibitory concentration: 5330 nM
For compound 4 the middle estimate is 2.1-fold (0.31 log units) above the measured one; low and high end bracket the measured number.
By their numbers in this assay, from the lowest: compounds 4, 2 and 3 (each within the scatter of the next, the first and the last beyond it). At a limit, above all of these: compound 1.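

Going by these compounds alone, on the aryl ring of the urea, at the place meta to a large group, chloro in place of methyl is the first change of one substituent here to go beyond the scatter in this assay: a 2.7-fold lower number from compound 3 to compound 4 (0.44 log units; beyond the scatter). Within the data shown here, a single substituent on this ring can therefore shift the number, although a 1.9-fold lower number from compound 2 to compound 4 (0.28 log units; within the scatter) gives no order for that pair. The cyclohexyl urea remains a limit, so an at least 7.5-fold lower number from compound 1 to compound 4 (0.87 log units; beyond the scatter) is a bound and not an exact size: the limit of > 40000 nM in this assay, at which 1 of the 4 values shown sits.

From the compounds shown here alone, whether the lower number belongs to chloro alone stays open; fluoro, methoxy, trifluoromethyl or an amine at the same place would test this. The compounds shown also leave open how the number responds to changes on the shared core.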